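The compounds below may be only part of what the source reports. "The series", "measured", "known", "first", "only" and "open" are said of these compounds alone.

Of the compounds shown here, three have been measured in a functional assay on the whole organism for inhibition, with Rattus norvegicus as the target, read by paw edema, with a stated time of 2 h, at a dose of 50 mg/kg; on this read-out lower numbers stand for less inhibition and higher numbers for more inhibition at the one dose given (going by the name of the read-out). Compound 1 `CC(=O)c1c(NNc2ccc(Cl)cc2)cc(C)oc1=O` gives 57.3%. Compound 2 `CC(=O)c1c(NNc2nc(C)cc(C)n2)cc(C)oc1=O` gives 61.8%. Compound 3 `Cc1cc2nn(-c3ccccc3)c(C)c2c(=O)o1`, built on a different core from the other two, gives 55.1%. On these numbers compound 3 is not set apart: its gap to compound 1 and its gap to compound 2 both lie within the usual scatter of repeated measurements, so the three results cannot be told apart with any confidence.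

Compound 4 `Cc1cc2nn(-c3ccc(Cl)cc3)c(C)c2c(=O)o1` has not been measured. It differs from compound 3 in one place: chloro in place of hydrogen on an aromatic carbon. Among the measured compounds shown here, no pair of measured compounds shows the effect of this change on its own. Compound 1 does carry a chloro group, and in this assay compound 1 gives 57.3%, a number close to that of compound 3, but compound 1 also differs in its core, so it is only a loose guide. The step from compound 3 to compound 4 is expected to be small, a number 1.9 percentage points higher from compound 3 to compound 4 (within the scatter), with no direction beyond the scatter. Compound 4 is estimated to give 57% in this assay, likely between 47% and 67%.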

Compound 4, a percentage reported as inhibition, in the whole organism at one dose (the size of the read-out at that dose, not a potency): 59.6%
Compound 4: the middle estimate sits 2.6 percentage points below what was measured; measured number inside the range.
By their numbers in this assay, from the lowest: compounds 3, 1, 4 and 2 (each within the scatter of the next).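

Among the compounds shown here, this pair gives the first direct reading of chloro in place of hydrogen on an aromatic carbon, with the rest of the molecule unchanged; the place is a six-membered aromatic ring of carbon only, para to a large group. In this assay the change gives a number 4.5 percentage points higher from compound 3 to compound 4 (within the scatter), so chloro at this position is accepted without a shift that stands clear of the scatter. Nothing available here gives a reason for the size of this step.

Going by these compounds, it remains open whether another group at this same place, such as an amine, a methoxy group or a carboxylic acid, would move the number beyond the scatter. Readings at one dose and one time also leave open how compound 3 and compound 4 would compare at other doses.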